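Chloro to amino on a purine core: expected cytotoxicity

The source may hold more compounds than are shown below. What is called first, only, known or untested is meant among the compounds shown, and "the series" means these compounds.

Measured compounds:
compound 1 `Nc1nc(Cl)c2ncn(Cc3ccc(CCl)cc3)c2n1`: 70800 nM
compound 2 `ClCc1cccc(Cn2cnc3c(Cl)nc(Cl)nc32)c1`: 55000 nM
compound 3 `ClCc1ccc(Cn2cnc3c(Cl)nc(Cl)nc32)cc1`: 45700 nM

These three were tested in a functional assay on PC-3 cells (Homo sapiens) for cytotoxicity, read by sulforhodamine B assay, with a stated time of 48 h; on this read-out higher numbers stand for lower toxicity in this test and lower numbers for higher toxicity in this test. All three numbers lie within the scatter of one another, so no order among them can be read. One structural change has already been measured: amino in place of chloro on an aromatic carbon. It gave a 1.5-fold higher number from compound 3 to compound 1 (0.19 log units; within the scatter). The difference between the cores of compound 2 and compound 3 is not broken down here. The unmeasured compound 4 `Nc1nc(Cl)c2ncn(Cc3cccc(CCl)c3)c2n1` carries the same change on the core of compound 2: amino in place of chloro on an aromatic carbon. Since the place is described in identical words, the step from compound 2 to compound 4 is expected to resemble the earlier one, giving an estimated 1.4-fold higher number from compound 2 to compound 4 (0.13 log units; within the scatter). Compound 4 is therefore expected to show about 75000 nM, likely between 40000 nM and 140000 nM.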

Compound 4, concentration lethal to 50% of the cells: 63100 nM
Compound 4: middle estimate off by 1.2-fold (0.08 log units), on the high side, within the range that was stated.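

In this assay, amino in place of chloro on an aromatic carbon gives a 1.1-fold higher number from compound 2 to compound 4 (0.06 log units; within the scatter). Set beside the same change on the other core, this step cannot be told apart from the earlier one: the same change on two cores in this assay, a 1.5-fold higher number (0.19 log units; within the scatter) from compound 3 to compound 1 and a 1.1-fold higher number (0.06 log units; within the scatter) from compound 2 to compound 4, 1.4-fold (0.13 log units) apart, within the scatter of two such steps. This shows that the change stayed within the scatter on both of these cores, but it does not show that a larger step would carry over from one core to another, and two cores make no rule for a wider series. The compounds shown leave open whether a different group in that place, such as a methoxy group or a longer amine, would give a step beyond the scatter.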